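Ester side chain swap on a dihydropyridine calcium channel antagonist

The compounds below may be only part of what the source reports. "The series", "measured", "known", "first", "only" and "open" are said of these compounds alone.

Compound 1 `CCOC(=O)C1=C(C)NC(C)=C(C(=O)OCCOC)C1c1cccc([N+](=O)[O-])c1` gives 16 nM in a functional assay on HEK293 cells for antagonist activity at Voltage-dependent L-type calcium channel subunit alpha-1C (Oryctolagus cuniculus), read by FLIPR; a higher number here means a weaker inhibitor, a lower number a stronger inhibitor. Compound 2 `COC(=O)C1=C(C)NC(C)=C(C(=O)OCC(C)[N+](=O)[O-])C1c1cccc([N+](=O)[O-])c1` gives 108 nM in this assay.

Compound 2 stands as the higher of the two numbers shown, and its gap to compound 1 lies beyond the scatter of the measurement, so compound 2 is the weaker inhibitor of the pair. Compound 3 `COC(=O)C1=C(C)NC(C)=C(C(=O)OCCOc2ccccc2Cl)C1c1cccc([N+](=O)[O-])c1` has not yet been measured in this assay. Its difference from compound 2 is (2-chlorophenoxy)methyl in place of 1-nitroethyl on a saturated chain carbon bound to an oxygen next to a carbonyl group. Among the measured compounds shown here, no step between measured compounds isolates this change, so the expectation rests on the two values shown. Because compound 1 with its different ester chain gives 16 nM, a compound 3 carrying yet another chain on the same saturated carbon is expected to move back toward that range, with a step of a 3.6-fold lower number from compound 2 to compound 3 (0.56 log units; beyond the scatter) toward a stronger inhibitor. Compound 3 is thus estimated at 30 nM, within 8 nM to 120 nM.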

Compound 3, half-maximal inhibitory concentration: 19 nM
Estimate against measurement, compound 3: 1.6-fold (0.20 log units) above, within the range that was stated.
By their numbers in this assay, from the lowest: compounds 1 and 3 (each within the scatter of the next); then compound 2.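

In this assay, putting (2-chlorophenoxy)methyl in place of 1-nitroethyl on a saturated chain carbon bound to an oxygen next to a carbonyl group gives a 5.7-fold lower number from compound 2 to compound 3 (0.75 log units; beyond the scatter), toward a stronger inhibitor. This is the only step shown that changes this one place alone, and it shows that the position accepts a group of 9 heavy atoms carrying a six-membered aromatic ring of carbon only, in place of one of 5 heavy atoms with no ring, without any loss of inhibition. No measurement here explains the gain.

The ring, the chlorine and the ether oxygen all enter together, so this step cannot assign the change to any one of them. From the compounds shown here alone, how an unsubstituted phenoxy group or a chain ending in a tertiary amine would behave at this position remains open.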